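A few compounds are considered here, and "the series" means these few. Any claim that something is new, unique, unknown or untested is made for them only; others in the source may bear on it.

Measured so far in a functional assay on A549 cells (Homo sapiens) for inhibition, read by MTT assay, with a stated time of 72 h; a higher number here means a weaker inhibitor, a lower number a stronger inhibitor:
compound 1, `CN(C(=O)NC(=O)c1cccc(C(F)(F)F)c1)c1nc(C(F)(F)F)c(C(=O)N/N=C/c2cccc(C(F)(F)F)c2)s1`, gives 8.16 ug/mL;
compound 2, `CN(C(=O)NC(=O)c1cccc(C(F)(F)F)c1)c1nc(C(F)(F)F)c(C(=O)N/N=C/c2ccccc2C(F)(F)F)s1`, gives 12.1 ug/mL;
compound 3, `Cc1nc(N(C)C(=O)NC(=O)c2ccc(Cl)cc2Cl)sc1C(=O)N/N=C/c1ccc(C(F)(F)F)cc1`, gives 30.2 ug/mL.

Among these three numbers compound 1 has the lowest. Its nearest neighbour is compound 2, reached by a 1.5-fold higher number from compound 1 to compound 2 (0.17 log units; within the scatter), a step that stays within the usual scatter, so the two cannot be ranked against each other. Compound 3 stands a clear distance further up, but it differs from compound 1 in more than one place, so no single change can be read from that gap.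

Compound 4, `CN(C(=O)NC(=O)c1c(F)cccc1F)c1nc(C(F)(F)F)c(C(=O)N/N=C/c2cccc(C(F)(F)F)c2)s1`, differs from compound 1 in one place: 2,6-difluorophenyl in place of 3-(trifluoromethyl)phenyl on a carbonyl carbon. Within the data shown here, this change sits on the carbonyl carbon whose other neighbour is the amide-type nitrogen, not on the carbon with a double bond to nitrogen where the one measured step was taken. That step from compound 1 to compound 2 therefore does not speak to it directly, and it was small in any case. Among the measured compounds shown here, no other measured pair isolates this position. With nothing pointing firmly either way, the expected outcome for compound 4 is a step of modest size, a 1.5-fold higher number from compound 1 to compound 4 (0.17 log units; within the scatter), leaning towards a somewhat higher number, with the wide uncertainty that such a lack of guidance brings. In this assay compound 4 is estimated at 12 ug/mL, within a range from 5 ug/mL to 30 ug/mL.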

Compound 4, half-maximal inhibitory concentration: 27.6 ug/mL
Beside the measured number, compound 4's estimate is 2.3-fold (0.36 log units) below it; the range from low to high includes it.
By their numbers in this assay, from the lowest: compounds 1 and 2 (each within the scatter of the next); then compounds 4 and 3 (each within the scatter of the next).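

In this assay, replacing the 3-(trifluoromethyl)phenyl on the carbonyl carbon with 2,6-difluorophenyl gives a 3.4-fold higher number from compound 1 to compound 4 (0.53 log units; beyond the scatter), a modest change but one that clearly exceeds the usual scatter. This is the first single change among the compounds shown to move the number beyond that scatter, since the earlier step at the carbon with a double bond to nitrogen, a 1.5-fold higher number from compound 1 to compound 2 (0.17 log units; within the scatter), could not be told apart from repeat variation; the group on this carbonyl carbon therefore matters to the result, and here the 2,6-difluorophenyl group is the weaker of the two. The two groups match in their counted features, with one six-membered aromatic ring, no hydrogen-bond donors or acceptors and no net charge, differing only in their atoms, and no available evidence explains the change.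

This single swap alters both the kind of substituent and where it sits on the ring, so the compounds shown cannot separate those two differences. As far as these compounds go, how a plain phenyl, or a phenyl bearing an amine or a carboxylic acid, would behave on this carbonyl carbon also remains open.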